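A few compounds are considered here, and "the series" means these few. Any claim that something is new, unique, unknown or untested is made for them only; others in the source may bear on it.

Measured so far in a physicochemical assay for solubility, at pH 7.4; on this read-out higher numbers stand for higher solubility and lower numbers for lower solubility:
Compound 1 `Cc1csc(C(=O)N[C@H]2CN(S(=O)(=O)c3ccccc3)C[C@@H]2C(=O)N[C@H]2CCCNC2)n1`: 847000 nM
Compound 2 `O=C(N[C@H]1CN(S(=O)(=O)c2ccccc2)C[C@@H]1C(=O)N[C@H]1CCCNC1)c1cc(C2CC2)n[nH]1`: 861000 nM
Compound 3 `O=C(N[C@H]1CN(S(=O)(=O)c2ccccc2)C[C@@H]1C(=O)N[C@H]1CCCNC1)c1cc(-c2ccccc2)on1`: 94000 nM

Compound 3 has the lowest number of the three, and compound 1 and compound 2 both lie clearly above it. Compound 4 `O=C(N[C@H]1CN(S(=O)(=O)c2ccccc2)C[C@@H]1C(=O)N[C@H]1CCCNC1)c1cc(-c2ccc(Cl)cc2)on1` has not yet been measured. It differs from compound 3 in one place: chloro in place of hydrogen on an aromatic carbon. Chloro takes the place of hydrogen on an aromatic carbon, para to a large group, so phenyl becomes 4-chlorophenyl.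

Among the compounds with values here, no measured step makes this exact change, so the evidence is indirect. The closest steps are the two that brought in the 5-phenyl-1,2-oxazol-3-yl group: a 9.0-fold lower number from compound 1 to compound 3 (0.95 log units; beyond the scatter) and a 9.2-fold lower number from compound 2 to compound 3 (0.96 log units; beyond the scatter). Both are modest and almost equal in size. The remaining step, a 1.0-fold higher number from compound 1 to compound 2 (0.01 log units; within the scatter), swaps two other groups and stays within the scatter.

Adding a single chlorine is a much smaller edit than replacing a whole group. Starting from compound 3 at 94000 nM, a smaller move in this assay in the same downward direction therefore seems the best guess, though it could prove little more than scatter. The expected change is a 2.4-fold lower number from compound 3 to compound 4 (0.37 log units; beyond the scatter). For compound 4 the estimated value is 40000 nM, with an expected range from 12000 nM to 100000 nM.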

Compound 4, solubility: 12000 nM
Compound 4: the middle estimate sits 3.3-fold (0.52 log units) above what was measured; the measured number falls inside the stated range.
By their numbers in this assay, from the lowest: compound 4; then compound 3; then compounds 1 and 2 (each within the scatter of the next).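

In this assay, one chlorine on an aromatic carbon, para to a large group, turns phenyl into 4-chlorophenyl and gives a 7.8-fold lower number from compound 3 to compound 4 (0.89 log units; beyond the scatter). This shows that a change of a single heavy atom at this place can register as a modest step, the same size class as exchanging the whole group on the carbonyl carbon in a 9.0-fold lower number from compound 1 to compound 3 (0.95 log units; beyond the scatter). With the chlorine in place, the whole-group exchanges become large steps, a 71-fold lower number from compound 1 to compound 4 (1.85 log units; beyond the scatter) and a 72-fold lower number from compound 2 to compound 4 (1.86 log units; beyond the scatter), so 5-(4-chlorophenyl)-1,2-oxazol-3-yl sets compound 4 clearly apart from compound 1 and compound 2.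

The compounds shown leave open whether this is particular to chlorine, or whether fluoro, methoxy or an amine on the same aromatic carbon would move the number as far, or even in the same direction. Nothing measured here goes beyond the numbers themselves to account for the drop.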